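Capping the Free Hydroxyl of Compound 1

The compounds below may be only part of what the source reports. "The series", "measured", "known", "first", "only" and "open" are said of these compounds alone.

Compound 1 `CCCC[C@H](O)/C=C\[C@@H]1OC(=O)C=C[C@@H]1OC(C)=O` is the starting point here. In a functional assay on Col1 cells (Homo sapiens) for cytotoxicity, read by sulforhodamine B assay, with a stated time of 72 h (a lower number here means that less compound is needed, a higher number that more compound is needed for the effect), compound 1 gives 1.1 ug/mL, the lowest of the two numbers in hand. Compound 2 `CCCC[C@H](OC(C)=O)[C@@H](O)[C@H](O)[C@@H]1OC(=O)C=C[C@@H]1OC(C)=O` is the only measured companion and differs from compound 1 in more than one place, so the two are compared only by what their values show: in this assay compound 2 gives 5.1 ug/mL, a gap beyond the scatter. Compound 3 `CCCC[C@@H](/C=C\[C@@H]1OC(=O)C=C[C@@H]1OC(C)=O)OC(C)=O` has not yet been measured. It differs from compound 1 by a single change: acetyl in place of hydrogen on an oxygen on a saturated carbon. Among the measured compounds shown here, no measured pair shows this change on its own, so there is no measured step to lean on. The expected step is small, a 1.8-fold higher number from compound 1 to compound 3 (0.26 log units; within the scatter), probably within the scatter, with the number perhaps drifting a little upward. For compound 3 the estimate in this assay is 2 ug/mL, with a range from 0.7 ug/mL to 6 ug/mL.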

Compound 3, concentration for half-maximal effect: 1 ug/mL
Compound 3: the middle estimate sits 2.0-fold (0.30 log units) above what was measured; measured number inside the range.
By their numbers in this assay, from the lowest: compounds 3 and 1 (each within the scatter of the next); then compound 2.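

Compound 1 and compound 2 differ in more than one place, so they could not show what this hydroxyl contributes on its own. The change from hydroxy to acetoxy now gives a single readable step in this assay: a 1.1-fold lower number from compound 1 to compound 3 (0.04 log units; within the scatter). On an oxygen on a saturated carbon, the hydrogen can therefore be exchanged for acetyl while the two numbers stay within the scatter of each other, and no measurement here explains why.

The compounds shown leave open whether this oxygen would accept a group other than acetyl, such as benzoyl or a longer ester chain. Going by these compounds, it also remains unknown how the number would respond if an amine or a carboxylic acid stood at this carbon in place of the oxygen.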